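The source may report more compounds than this note shows. Statements on the series, on what has been measured and on what is new or still open speak of the compounds shown alone.

Series notes. In an ADME assay on J774.A1 cells (Mus musculus) for cytotoxicity, read by MTT assay, with a stated time of 48 h (a lower number here means that less compound is tolerated, a higher number that more compound is tolerated), compound 1 `O=C(Nc1ccccc1)c1c([N+](=O)[O-])noc1-c1ccc([N+](=O)[O-])cc1` gives "not determined" (no result reported) and so contributes no number. Going by the values given here, compound 2 `O=C(Nc1ccccc1)c1c([N+](=O)[O-])noc1-c1ccc(Cl)cc1` is the only member with a value: in this assay compound 2 gives 89300 nM, and it stands alone, with nothing to compare it against. Compound 3 `COc1cccc(CNC(=O)c2c([N+](=O)[O-])noc2-c2ccc(Cl)cc2)c1` is yet to be tested. It differs from compound 2 in one place: 3-methoxybenzyl in place of phenyl on an amide-type nitrogen. Among the compounds with values here, no measured pair shows what such a change does to the tolerated concentration, so there is no step to lean on. The expected step of a 1.3-fold lower number from compound 2 to compound 3 (0.11 log units; within the scatter) is taken to lie inside the usual scatter, with no direction beyond it. Compound 3 is therefore estimated at 70000 nM in this assay, with a range from 25000 nM to 200000 nM. A reported limit instead of a number remains possible for compound 3.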

Compound 3, half-maximal cytotoxic concentration: 68600 nM
Compound 3: middle estimate off by 1.0-fold (0.01 log units), on the high side; low and high end bracket the measured number.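

In this assay, the series now has its first readable step on the amide-type nitrogen: a 1.3-fold lower number from compound 2 to compound 3 (0.11 log units; within the scatter). Going from phenyl, with 6 heavy atoms and 0 hydrogen-bond acceptors, to 3-methoxybenzyl, with 9 heavy atoms and 1 hydrogen-bond acceptor, therefore gives no difference beyond the scatter in the tolerated concentration, so on this single pair the position takes the bigger group without a readable shift. No supporting data bear on why the two compounds read alike.

The compounds shown cannot separate the methoxy group from the benzyl part of 3-methoxybenzyl, as both enter together in compound 3. Going by these compounds, whether an amine, a carboxylic acid or a longer chain on the amide-type nitrogen would also stay within the scatter of compound 2 remains open.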